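Removing the furan ring: what the cell tolerance may show

The source may hold more compounds than are shown below. What is called first, only, known or untested is meant among the compounds shown, and "the series" means these compounds.

Of the compounds shown here, two have been tested in an ADME assay on Vero cells (Chlorocebus sabaeus) for cytotoxicity, read by sulforhodamine B assay, with a stated time of 3 days; a lower number here means that less compound is tolerated, a higher number that more compound is tolerated. Compound 1, `COc1cc(C2C(C(=O)Nc3ccc(Cl)cc3)=C(C)NC(C)=C2C(=O)Nc2ccc(Cl)cc2)ccc1O`, gives 250 ug/mL. Compound 2, `COc1ccc(NC(=O)C2=C(C)NC(=O)NC2c2ccco2)cc1`, gives 210 ug/mL. Compound 2 thus stands at the lower end of the two numbers, but its gap to compound 1 is within the usual scatter of repeated measurements, so the two values are best read as one and the same level of tolerance.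

Compound 3, `COc1ccc(NC(=O)C2=C(C)NC(=O)NC2)cc1`, has not yet been measured. It differs from compound 2 in one place: hydrogen in place of furan-2-yl on a saturated ring carbon. The change simply takes away the furan-2-yl group and leaves a hydrogen in its place; the rest of the molecule is kept.

Going by the values given here, no measured pair with a single change is available, so nothing in the data shows how such a removal moves this assay. Given that compound 1 and compound 2, with quite different shapes, sit at the same level, the expected step of a 1.1-fold higher number from compound 2 to compound 3 (0.06 log units; within the scatter) is none beyond the scatter. Compound 3 is therefore estimated at 240 ug/mL, with a range from 120 ug/mL to 480 ug/mL.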

Compound 3, half-maximal cytotoxic concentration: 200 ug/mL
Estimate against measurement, compound 3: 1.2-fold (0.08 log units) above, and the stated range covers the measured number.
By their numbers in this assay, from the lowest: compounds 3, 2 and 1 (each within the scatter of the next).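

Going by these compounds alone, this pair gives the first reading of a single change. In this assay, taking away furan-2-yl, a group of 5 heavy atoms with one five-membered aromatic ring, and leaving hydrogen on the saturated ring carbon gives a 1.1-fold lower number from compound 2 to compound 3 (0.02 log units; within the scatter), so compound 2 and compound 3 stand at one level of tolerance and the furan-2-yl group makes no difference here that can be told from the scatter. Compound 1 and compound 2 could not show this, as they differ in more than one place, whereas this pair isolates the one position; no measurement at hand bears on why the number holds at this level.

Going by these compounds, only furan-2-yl and hydrogen have been compared on this saturated ring carbon, so it remains open whether a phenyl ring, an amine, a carboxylic acid or a longer chain placed there would stay at the same level. It also remains open whether any group at this position can move the number beyond the scatter at all, as the single step shown stays within it.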